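The source may report more compounds than this note shows. Statements on the series, on what has been measured and on what is new or still open speak of the compounds shown alone.

Of the compounds shown here, two built on a shared core have been tested in an assay on mitochondria from L6 cells (Rattus norvegicus) for activation, with a stated time of 90 min; a higher number here means that more compound is needed for the effect, a lower number that less compound is needed. Compound 1 `Cc1ccc(Nc2nc3nonc3nc2Nc2ccc(C)cc2)cc1` gives > 20000 nM in this assay, which is a limit of the measurement and not a number. Compound 2 `Fc1ccccc1Nc1nc2nonc2nc1NCCC(F)(F)F` gives > 100000 nM in this assay, again a limit rather than a number. Compound 2 thus sits at the limit of > 100000 nM in this assay, at which 1 of the 2 values shown sits. The other value shown sits at the limit of > 20000 nM in this assay, at which 1 of the 2 values shown sits, so neither compound produced a measurable effect. Compound 3 `Fc1ccccc1Nc1nc2nonc2nc1Nc1ccccn1` is the next compound to be measured in this assay. It differs from compound 2 in one place (pyridin-2-yl in place of 3,3,3-trifluoropropyl on a nitrogen on an aromatic ring). Within the data shown here, no measured step exists to suggest the size of this change. With both measured values at limits, the step of a number no higher from compound 2 to compound 3 (the limit leaves the size open) is expected to be none beyond the scatter. Compound 3 is estimated at 100000 nM, expected to fall between 20000 nM and 500000 nM.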

Compound 3, half-maximal effective concentration: 9000 nM
Compound 3: middle estimate off by 11-fold (1.05 log units), on the high side, and the stated range ends above it.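

Putting pyridin-2-yl in place of 3,3,3-trifluoropropyl on this nitrogen gives an at least 11-fold lower number from compound 2 to compound 3 (1.04 log units; beyond the scatter) in this assay, so the group on this nitrogen can decide whether a measurable effect appears at all. Of the three compounds, only compound 3 has a real number rather than a limit, which makes this the first change shown to bring a response. The true size of the step stays open on one side, since the value of compound 2 is a limit: the limit of > 100000 nM in this assay, at which 1 of the 3 values shown sits.

The compounds shown do not tell whether the step goes with the aromatic ring itself or with the nitrogen inside it, a question that a plain phenyl group on this nitrogen would address. Going by these compounds, whether pyridin-3-yl or pyridin-4-yl, which carry that ring nitrogen elsewhere, would give a similar value also remains open.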